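Fucosidase inhibition of hydroxymethyl-pyrrolidine aryl compounds, mirror-image pair

The source may hold more compounds than are shown below. What is called first, only, known or untested is meant among the compounds shown, and "the series" means these compounds.

Measured so far:
Compound 1, `COc1cccc([C@@]2(CO)NC[C@H](O)[C@H]2O)c1`: 1.6%
Compound 2, `COc1ccc([C@]2(CO)NC[C@@H](O)[C@@H]2O)cc1OC`: 0%

Going by the values given here, in an assay on isolated protein for inhibition of tissue alpha-L-fucosidase (Bos taurus), tested at 1000 uM (a lower number here means less inhibition, a higher number more inhibition at the concentration tested (going by the name of the read-out)), compound 2 gives 0%, the lowest of the two numbers recorded; the only neighbour, compound 1, sits higher by an amount that lies within the usual scatter of this assay, so the two cannot be told apart. Neither measured compound shows inhibition to speak of at the concentration tested.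

Compound 3, `COc1ccc([C@@]2(CO)NC[C@H](O)[C@H]2O)cc1OC`, has not yet been measured in this assay. Relative to compound 2 the change is: the two compounds have the same atoms and bonds and differ only in configuration as drawn: 3 of 3 stereo elements differ (all stereocentres are inverted: mirror images); a stereocentre at a saturated ring carbon is drawn R in compound 2 and S in compound 3; a stereocentre at a saturated ring carbon is drawn R in compound 2 and S in compound 3; a stereocentre at a saturated ring carbon is drawn R in compound 2 and S in compound 3.

Among the compounds with values here, no step between measured compounds is recorded, so the size of a mirror-image step is unknown here. Compound 3 is drawn in the same configuration as compound 1; in this assay compound 1 sits at 1.6%, which gives no sign that this configuration inhibits more. Compound 3 is therefore expected to stay near the floor, with a step of a number 3 percentage points higher from compound 2 to compound 3 (within the scatter) that is not expected to exceed the scatter. The estimate for compound 3 is 3%, in the range 0% to 15%.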

Compound 3, a percentage reported as inhibition, at one concentration (the size of the read-out at that concentration, not a potency): 0.5%
Compound 3: the middle estimate sits 2.5 percentage points above what was measured, within the range that was stated.
By their numbers in this assay, from the lowest: compounds 2, 3 and 1 (each within the scatter of the next).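

In this assay, inverting all three stereocentres gives a number 0.5 percentage points higher from compound 2 to compound 3 (within the scatter), so the mirror-image step now has a size, and it does not separate the two forms at the concentration tested. The reading of this step as a test of configuration alone rests on one point: the fact that compounds 2 and 3 differ only in the configuration as drawn. Methoxy in place of hydrogen on an aromatic carbon comes with a number 1.1 percentage points lower from compound 1 to compound 3 (within the scatter), so this change cannot be told from scatter either, and neither step lifts the series off the floor.

Every compound shown carries methoxy on the aromatic part and hydroxymethyl on the core. As far as these compounds go, whether an amine or a carboxylic acid in place of methoxy, or a longer chain in place of hydroxymethyl, would produce a readable signal in this assay remains open.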